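Cytotoxicity notes: methylsulfanyl for methoxy on the core

A few compounds are considered here, and "the series" means these few. Any claim that something is new, unique, unknown or untested is made for them only; others in the source may bear on it.

Compound 1 `COc1ncnc(Nc2ccc(Cl)c(OCC=C(C)C)c2)n1` gives 18000 nM in an ADME assay on MT2 cells (Homo sapiens) for cytotoxicity; on this read-out lower numbers stand for higher toxicity in this test and higher numbers for lower toxicity in this test. Compound 2 `COc1ncnc(Nc2ccc(C#N)c(OCC=C(C)C)c2)n1` gives 42000 nM in this assay, the highest of the two plain numbers; the step of a 2.3-fold higher number from compound 1 to compound 2 (0.37 log units; beyond the scatter) brings cyano in place of chloro. Compound 3 `COc1nc(Nc2ccc(C#N)c(OCC=C(C)C)c2)nc(OC)n1` reaches only the limit > 100000 nM in this assay, and the limit of > 100000 nM in this assay, at which 1 of the 3 values shown sits, marks where it sits. The step of an at least 2.3-fold higher number from compound 2 to compound 3 (0.37 log units; beyond the scatter) adds methoxy on the core. Compound 4 `CSc1ncnc(Nc2ccc(C#N)c(OCC=C(C)C)c2)n1` differs from compound 2 by methylsulfanyl in place of methoxy on an aromatic carbon. Among the compounds with values here, no measured step swaps one group for another at this place, so the two measured steps give no direct guide; the modest size of both suggests that for compound 4 the step of a 1.1-fold higher number from compound 2 to compound 4 (0.03 log units; within the scatter) is expected to stay within the scatter. Compound 4 is estimated at 45000 nM, between 20000 nM and 100000 nM.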

Compound 4, half-maximal cytotoxic concentration: 8400 nM
Estimate against measurement, compound 4: 5.4-fold (0.73 log units) above; measured number outside the range, below it.
By their numbers in this assay, from the lowest: compound 4; then compound 1; then compound 2. At a limit, above all of these: compound 3.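

In this assay methylsulfanyl in place of methoxy on the core gives a 5.0-fold lower number from compound 2 to compound 4 (0.70 log units; beyond the scatter) and is the only step shown that lowers the number, meaning higher toxicity in this test. The leaving and entering groups match in heavy-atom count and hydrogen-bond acceptors, so this read-out responds at this carbon to sulfur in place of oxygen alone. Nothing shown gives a reason for this shift.

Open, on these data alone, is how an amine or a longer sulfur-linked chain would read at this carbon. Also open, as far as these compounds go, is whether methylsulfanyl lowers the number likewise on the core of compound 3.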